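The compounds below may be only part of what the source reports. "The series", "measured", "known", "first", "only" and "open" are said of these compounds alone.

In a functional assay on HeLa cells for agonist activity at 5-hydroxytryptamine receptor 6 (Homo sapiens), read by immunoassay (on this read-out higher numbers stand for an effect only at larger amounts of compound and lower numbers for an effect already at smaller amounts), compound 1 `Cc1c(S(=O)(=O)c2ccccc2)c2cccnc2n1CCN` gives 20 nM, while compound 2 `Cc1c(S(=O)(=O)c2ccccc2)c2cccnc2n1CCN(C)C` gives 47 nM. The two differ by amino in place of dimethylamino on a saturated chain carbon, two bonds along the chain from an aromatic nitrogen and the measured step is a 2.4-fold lower number from compound 2 to compound 1 (0.37 log units; beyond the scatter). Compound 3 `CN(C)CCn1cc(S(=O)(=O)c2cc(Cl)cc(Cl)c2)c2cccnc21` carries a core whose difference from the core of compound 2 is not broken down here; in this assay compound 3 gives 28 nM, a value within the scatter of both compound 1 and compound 2. Compound 4 `NCCn1cc(S(=O)(=O)c2cc(Cl)cc(Cl)c2)c2cccnc21` has not yet been measured. It differs from compound 3 by amino in place of dimethylamino on a saturated chain carbon, two bonds along the chain from an aromatic nitrogen, the same change as that from compound 2 to compound 1, at the same place. Because the step of a 2.4-fold lower number from compound 2 to compound 1 (0.37 log units; beyond the scatter) was modest yet beyond the scatter, the expected step from compound 3 to compound 4 is similar, namely a 2.3-fold lower number from compound 3 to compound 4 (0.37 log units; beyond the scatter). Compound 4 is therefore estimated in this assay at 12 nM, expected to lie between 5 nM and 30 nM.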

Compound 4, half-maximal effective concentration: 35 nM
For compound 4 the middle estimate is 2.9-fold (0.46 log units) below the measured one; the whole stated range lies below it.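

In this assay, the exchange of dimethylamino for amino on the second core gives a 1.3-fold higher number from compound 3 to compound 4 (0.10 log units; within the scatter). Set beside the earlier step, this result does not match it: the same change on two cores in this assay, a 2.4-fold lower number (0.37 log units; beyond the scatter) from compound 2 to compound 1 and a 1.3-fold higher number (0.10 log units; within the scatter) from compound 3 to compound 4, 2.9-fold (0.47 log units) apart, beyond the scatter of two such steps The size of the step therefore did not carry over between these two cores, but two pairs do not show which feature of the cores sets it, or how the change would behave on any further core.

The compounds shown leave open whether the methyl group of compound 1 or the two chlorines of compound 3 matter more for this step, since neither is seen alone. Also open, on these data alone, is how methylamino, or a longer chain ending in an amine, would behave on either core.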